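Cinnamoyl in place of dichlorobenzoyl on the ring nitrogen carbonyl

This account rests on a few compounds, and the source may have more. Where it says the series, first, only, none or still open, it means among the compounds named here.

Two compounds of the series have numbers in a functional assay on NCI-H1975 cells (Homo sapiens) for inhibition, read by sulforhodamine B assay, tested at 10 uM; on this read-out lower numbers stand for less inhibition and higher numbers for more inhibition at the one concentration tested (going by the name of the read-out). Compound 1 `CN1CCN(c2ccc(C3=NN(C(=O)/C=C/c4ccccc4)C(c4ccc(N(C)C)cc4)C3)cc2)CC1` gives 81% in this assay. Compound 2 `CN(C)c1ccc(C2CC(c3ccc(-n4cncn4)cc3)=NN2C(=O)c2cc(Cl)cc(Cl)c2)cc1` gives 8.4% in this assay; it stands lowest of the two, and its nearest neighbour, compound 1, lies higher by a gap beyond the scatter. The two compounds differ in more than one place, so their values alone do not tell which change carries the gap.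

Compound 3 `CN(C)c1ccc(C2CC(c3ccc(-n4cncn4)cc3)=NN2C(=O)/C=C/c2ccccc2)cc1` is compound 2 with 2-phenylethenyl in place of 3,5-dichlorophenyl on a carbonyl carbon. The (2-phenylethenyl)carbonyl that enters is also present in compound 1, though compound 1 differs from compound 3 elsewhere as well. Going by the values given here, no step between measured compounds isolates this change, so its size is unknown. An upward step is expected for compound 3 in this assay, of moderate to large size, because compound 1 gives 81% with the same carbonyl substituent, but the expectation is wide. The step expected from compound 2 to compound 3 is a number 36.6 percentage points higher from compound 2 to compound 3 (beyond the scatter). Compound 3 is estimated at 45% in this assay, within a range from 10% to 80%.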

Compound 3, a percentage reported as inhibition, at one concentration (the size of the read-out at that concentration, not a potency): -2.3%
For compound 3 the middle estimate is 47.3 percentage points above the measured one; measured number below the stated range.
By their numbers in this assay, from the lowest: compound 3; then compound 2; then compound 1.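

In this assay, 2-phenylethenyl in place of 3,5-dichlorophenyl on a carbonyl carbon gives a number 10.7 percentage points lower from compound 2 to compound 3 (beyond the scatter), a modest step, so with 1H-1,2,4-triazol-1-yl on the aromatic carbon this carbonyl substituent brings no gain. With the (2-phenylethenyl)carbonyl held constant, 1H-1,2,4-triazol-1-yl in place of 4-methylpiperazin-1-yl on an aromatic carbon gives a number 83.3 percentage points lower from compound 1 to compound 3 (beyond the scatter), a large step that ties the high number of compound 1 to the 4-methylpiperazin-1-yl group within this pair, and shows that the (2-phenylethenyl)carbonyl alone does not carry it. Nothing at hand explains either step.

Going by these compounds alone, still open is whether the carbonyl change gives a step of similar size and direction when 4-methylpiperazin-1-yl sits on the aromatic carbon, as the only reading of that change has 1H-1,2,4-triazol-1-yl there. Also open, going by these compounds, is how much of the 4-methylpiperazin-1-yl group is needed, which a morpholine or an open-chain amine such as dimethylamino on the same aromatic carbon would begin to show in this assay.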